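From chloro to bromo: one swap on compound 1

The source may hold more compounds than are shown below. What is called first, only, known or untested is meant among the compounds shown, and "the series" means these compounds.

Compound 1 `O=C1NC(=S)/C(=C/c2ccc(Cl)cc2)S1` gives 35.8%
Compound 2 `O=C1NC(=S)/C(=C/c2cc(Cl)cc(Cl)c2Cl)S1` gives 39.7%
Compound 3 `O=C1NC(=S)/C(=C/c2ccccc2Br)S1` gives 22.9%

In a functional assay on NCI-H292 cells (Homo sapiens) for cytotoxicity, read by MTT assay, with a stated time of 72 h, tested at 5 ug/mL (on this read-out higher numbers stand for more inhibition of growth at the one concentration tested and lower numbers for less inhibition of growth), compound 1 lies within the usual scatter of compound 2, so these two cannot be told apart. Compound 3 falls below compound 1 by more than that scatter. Compound 1 therefore sits level with compound 2 and clear of compound 3.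

The next compound has not been measured yet. Compound 4 `O=C1NC(=S)/C(=C/c2ccc(Br)cc2)S1` keeps the shared core of compound 1 and changes one thing. The change bromo in place of chloro on an aromatic carbon puts bromo in place of chloro on an aromatic carbon, and nothing else differs.

Among the measured compounds shown here, no two measured compounds differ in only one place, so the data hold no direct measure of what this swap does. Compound 3 also carries a bromo group, but it differs from compound 1 in more than one place and is no clean comparison.

The best starting point is therefore compound 1 at 35.8% in this assay, and no change beyond the scatter is expected, in either direction. The estimated step (a number 1.8 percentage points lower from compound 1 to compound 4 (within the scatter)) is small and could easily turn out the other way. For compound 4 the expected value is 34% (range 20% to 48%).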

Compound 4, percent growth inhibition at one concentration: 16.6%
Beside the measured number, compound 4's estimate is 17.4 percentage points above it, outside the stated range (below it).
By their numbers in this assay, from the lowest: compounds 4 and 3 (each within the scatter of the next); then compounds 1 and 2 (each within the scatter of the next).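

Among the compounds shown here, compound 1 and compound 4 form the first pair here that differs in one place only, so the effect of this swap can now be read directly. In this assay, putting bromo in place of chloro on an aromatic carbon of a six-membered aromatic ring of carbon only, para to a group of 8 heavy atoms, gives a number 19.2 percentage points lower from compound 1 to compound 4 (beyond the scatter) and counts as a modest but real loss of growth inhibition at the one concentration tested. One heavy atom replaces one heavy atom, with no hydrogen-bond donors, acceptors or net charge on either group, yet the read-out still separates chloro from bromo at this place, and the data offer no measured explanation for the difference.

The compounds shown leave open how fluoro, a methoxy group or an amine at this same place would compare with chloro and bromo. They also leave open whether the same swap would produce a similar step at another place on the aromatic ring, as this single pair sets no general rule.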